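Swapping the distal aryl group: expected acid dissociation

A few compounds are considered here, and "the series" means these few. Any claim that something is new, unique, unknown or untested is made for them only; others in the source may bear on it.

Compound 1 `FC(F)(F)c1ccc(-c2ccc3c(NCCCNCc4ccco4)ccnc3c2)cc1`: 9.47
Compound 2 `COc1cccc(CNCCCNc2ccnc3cc(-c4ccc(C(F)(F)F)cc4)ccc23)c1O`: 9.47

In a physicochemical assay for acid dissociation, compound 1 gives 9.47, and compound 2 gives 9.47; compound 1 therefore stands level with compound 2 at the digits shown. Within the data shown here, the single measured step, no change at the digits printed from compound 1 to compound 2 (within the scatter), exchanged one group on the saturated chain carbon bound to the amine nitrogen and left the read-out unchanged within the scatter.

Compound 3 `c1coc(CNCCCNc2ccnc3cc(-c4cccc5ccccc45)ccc23)c1` has not yet been measured in this assay. It differs from compound 1 in one place: naphthalen-1-yl in place of 4-(trifluoromethyl)phenyl on an aromatic carbon. The chain with its two amine nitrogens is the same in compound 1 and compound 3.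

Among the measured compounds shown here, only one measured step is available, and it concerns a different part of the molecule, so it bears on this change only loosely. Still, because no change at the digits printed from compound 1 to compound 2 (within the scatter) showed no movement when a group was exchanged, and because the exchange in compound 3 leaves the amine-bearing chain untouched, the step of a number 0.03 log units higher from compound 1 to compound 3 (within the scatter) is expected to fall within the scatter. Compound 3 is estimated to give 9.5 in this assay, in the range 9.1 to 9.9.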

Compound 3, acid dissociation constant: 9.47
Estimate against measurement, compound 3: 0.03 log units above, and the stated range covers the measured number.
By their numbers in this assay, from the lowest: compounds 1, 2 and 3 (each within the scatter of the next).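

In this assay, replacing 4-(trifluoromethyl)phenyl with naphthalen-1-yl on an aromatic carbon of the shared core gives no change at the digits printed from compound 1 to compound 3 (within the scatter), so this read-out now has a second place in the molecule, away from the saturated chain carbon exchanged earlier, where a change of group leaves it within the scatter. The exchange is a substantial one in composition: the two groups have the same heavy-atom count, but the entering group has 2 six-membered aromatic rings of carbon only and no fluorine, while the leaving group has one such ring and 3 fluorine atoms, and even so the number stays level at the digits printed. No measurement available here accounts for this result.

The compounds shown leave open whether a group of another kind on this aromatic carbon, such as a carboxylic acid or a primary amine, would also leave the number level. They also leave open whether a longer chain between the two amine nitrogens would move it, and which nitrogen gives up the proton that the number reports.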